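Epimer of compound 3 at the saturated ring carbon

This account rests on a few compounds, and the source may have more. Where it says the series, first, only, none or still open, it means among the compounds named here.

Measured so far:
compound 1 `CN1CCC[C@H]1[C@@H]1COc2ccc(N)cc2O1` — 19 nM
compound 2 `CN1CCC[C@H]1[C@@H]1COc2ccc([N+](=O)[O-])cc2O1` — 4500 nM
compound 3 `CN(C)c1ccc2c(c1)O[C@@H]([C@@H]1CCCN1C)CO2` — 25000 nM

In an assay on membranes from HEK293 cells for displacement of a labelled ligand from Neuronal acetylcholine receptor; alpha3/beta4 (Homo sapiens), with a stated time of 5 min (on this read-out higher numbers stand for weaker inhibition and lower numbers for stronger inhibition), compound 1 gives 19 nM. Going by the values given here, compound 2 gives 4500 nM, and the single measured step, a 240-fold higher number from compound 1 to compound 2 (2.37 log units; beyond the scatter), is large. Compound 3 gives 25000 nM and stands with the highest number of the three, beyond the scatter from compound 2 and far beyond it from compound 1.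

Compound 4 `CN(C)c1ccc2c(c1)O[C@H]([C@@H]1CCCN1C)CO2` is the next one to be tested. It differs from compound 3 as follows: the two compounds have the same atoms and bonds and differ only in configuration as drawn: 1 of 2 stereo elements differ; a stereocentre at a saturated ring carbon is drawn S in compound 3 and R in compound 4. No measured step concerns a change of configuration; the only step shown, from compound 1 to compound 2, exchanges one group for another and so does not bear on this change. With nothing to lean on, the direction and size of the step in this assay cannot be drawn from the data. Compound 4 is therefore estimated at 12000 nM, within 2000 nM to 60000 nM, and the step of a 2.1-fold lower number from compound 3 to compound 4 (0.32 log units; beyond the scatter) is the expectation, with a wide range on either side.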

Compound 4, inhibition constant: 2200 nM
The estimate for compound 4 lay 5.5-fold (0.74 log units) above the measured number; the range from low to high includes it.
By their numbers in this assay, from the lowest: compound 1; then compound 4; then compound 2; then compound 3.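

In this assay the configuration at the saturated ring carbon proves to be a large effect on its own, an 11-fold lower number from compound 3 to compound 4 (1.06 log units; beyond the scatter), with the R drawing giving the lower number, and this step can be put down to that stereocentre alone because of the following: the fact that compounds 3 and 4 differ only in the configuration as drawn. With that configuration kept, dimethylamino on the aromatic carbon stays far from amino, a 120-fold higher number from compound 1 to compound 4 (2.06 log units; beyond the scatter), while its exchange for nitro gives only a modest step, a 2.0-fold lower number from compound 2 to compound 4 (0.31 log units; beyond the scatter). Among these three groups, amino therefore stands apart on that carbon, and the nitro and dimethylamino compounds lie much closer to each other.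

The compounds shown leave open whether a step of this size at the saturated ring carbon would also appear with amino or nitro on the aromatic carbon. They also leave open how methylamino or methoxy there would compare with amino.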